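Changing the aryl group on the nitrogen of compound 2

The source may report more compounds than this note shows. Statements on the series, on what has been measured and on what is new or still open speak of the compounds shown alone.

compound 1 `O=C1Nc2ccc(S(=O)(=O)N3CCOCC3)cc2/C1=N/c1ccc(O)cc1`: 27300 nM
compound 2 `O=C1Nc2ccc(S(=O)(=O)N3CCOCC3)cc2/C1=N/c1ccc(C(=O)O)cc1`: 23600 nM

Both compounds were tested in a functional assay on HCT-116 cells (Homo sapiens) for cytotoxicity, read by sulforhodamine B assay, with a stated time of 24 h; a higher number here means a weaker inhibitor, a lower number a stronger inhibitor. Among the measured compounds shown here, compound 2 stands level with the only other measured compound, and the two numbers cannot be told apart: the data show a 1.2-fold lower number from compound 1 to compound 2 (0.06 log units; within the scatter). Neither number can therefore be called the better one.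

The next compound, compound 3 `CC(=O)c1cccc(/N=C2\C(=O)Nc3ccc(S(=O)(=O)N4CCOCC4)cc32)c1`, keeps the shared core and changes the group on the double-bonded nitrogen: 3-acetylphenyl in place of 4-carboxyphenyl on a double-bonded nitrogen. In words, 3-acetylphenyl stands in place of 4-carboxyphenyl.

For the measured compounds named here, only one measured step bears on this change, and it bears only loosely. It is carboxy in place of hydroxy on an aromatic carbon, and it gave a 1.2-fold lower number from compound 1 to compound 2 (0.06 log units; within the scatter). Going by the values given here, no measured compound carries a 3-acetylphenyl group, so the data offer no direct evidence for it. With that single small step as the guide, no shift beyond the scatter is expected in this assay, in either direction.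

The estimated change is a 1.2-fold lower number from compound 2 to compound 3 (0.07 log units; within the scatter).

For compound 3 the expected value is 20000 nM, with an estimated range of 7000 nM to 50000 nM.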

Compound 3, half-maximal inhibitory concentration: 29000 nM
The estimate for compound 3 lay 1.5-fold (0.16 log units) below the measured number; the measured number falls inside the stated range.
By their numbers in this assay, from the lowest: compounds 2, 1 and 3 (each within the scatter of the next).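

In this assay, 3-acetylphenyl in place of 4-carboxyphenyl on the double-bonded nitrogen gives a 1.2-fold higher number from compound 2 to compound 3 (0.09 log units; within the scatter), and 3-acetylphenyl in place of 4-hydroxyphenyl gives a 1.1-fold higher number from compound 1 to compound 3 (0.03 log units; within the scatter), so all three compounds stand level. The aryl group here can thus differ in more than one way without the number leaving the scatter: the new group is a ketone rather than an acid, its name places the substituent at 3 rather than 4, and it has 0 hydrogen-bond donors where 4-carboxyphenyl has 1. Nothing available accounts for this level result.

Going by these compounds, what remains open is whether any group on this nitrogen can move the number beyond the scatter, for example a phenyl ring bearing an amine, or a longer carbon chain in place of the aryl ring. These three compounds also cannot separate the effect of the substituent's place on the ring from that of its identity, which a 4-acetylphenyl group would begin to address.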